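Ring exchange at the carbinol carbon in the dopamine transporter series

A few compounds are considered here, and "the series" means these few. Any claim that something is new, unique, unknown or untested is made for them only; others in the source may bear on it.

Measured so far:
compound 1 `Cc1ccc(C(O)CCN2CC=C(Cc3ccccc3)CC2)cc1` gives 30%
compound 2 `COc1ccc(C(O)CCN2CC=C(Cc3ccccc3)CC2)cc1` gives 57%
compound 3 `O=[N+]([O-])c1ccc(C(O)CCN2CC=C(Cc3ccccc3)CC2)cc1` gives 55%

All three numbers come from an assay on CHO cells for inhibition of sodium-dependent dopamine transporter (Homo sapiens), read by scintillation counting, with a stated time of 10 min, tested at 10 uM; on this read-out higher numbers stand for more inhibition at the one concentration tested (going by the name of the read-out) and lower numbers for less inhibition. Compound 2 stands highest of the three, though its gap to compound 3 is within the scatter, a number 2 percentage points lower from compound 2 to compound 3 (within the scatter); only compound 1 sits clearly apart, a number 27 percentage points higher from compound 1 to compound 2 (beyond the scatter), matched by a number 25 percentage points higher from compound 1 to compound 3 (beyond the scatter). Compound 4 `OC(CCN1CC=C(Cc2ccccc2)CC1)c1cccs1` differs from compound 2 by thiophen-2-yl in place of 4-methoxyphenyl on a saturated chain carbon bound to an oxygen on a saturated carbon and a saturated chain carbon. Among the measured compounds shown here, no measured step bears directly on this: each swaps one group on the six-membered ring, whereas here the ring itself is exchanged. The substituent steps span a modest range, so a step of similar size in either direction is plausible, and compound 4 is expected to land near the middle of the measured spread. The estimate for compound 4 is 40%, within 15% to 65%, an expected change of a number 17 percentage points lower from compound 2 to compound 4 (beyond the scatter).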

Compound 4, a percentage reported as inhibition, at one concentration (the size of the read-out at that concentration, not a potency): 52%
For compound 4 the middle estimate is 12 percentage points below the measured one; low and high end bracket the measured number.
By their numbers in this assay, from the lowest: compound 1; then compounds 4, 3 and 2 (each within the scatter of the next).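

The aryl ring at this position can be exchanged outright, not only substituted: thiophen-2-yl in place of 4-methoxyphenyl gives a number 5 percentage points lower from compound 2 to compound 4 (within the scatter), while in place of 4-methylphenyl it gives a number 22 percentage points higher from compound 1 to compound 4 (beyond the scatter). A five-membered aromatic ring with a sulfur therefore holds the level of compound 2 and stays clear of compound 1. Nothing available explains these numbers.

Open, going by these compounds, is whether a furan-2-yl, pyridin-2-yl or saturated cyclohexyl ring at this position would hold the same level. Also open, on these data alone, is how a methoxy group on the thiophene ring would read.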